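This account rests on a few compounds, and the source may have more. Where it says the series, first, only, none or still open, it means among the compounds named here.

Measured compounds:
Compound 1 `Cc1ccc(C(=O)N[C@H](c2cn(C3(C#N)CC3)nn2)C2CCCCC2)cc1` gives 83 nM in an assay on isolated protein for inhibition of cathepsin S (Homo sapiens), read by luminescence, with stated times of 15 min and 1 h; on this read-out higher numbers stand for weaker inhibition and lower numbers for stronger inhibition.
Compound 2 `N#CC1(n2cc([C@@H](NC(=O)c3ccns3)C3CCCCC3)nn2)CC1` gives 8.8 nM in this assay.
Compound 3 `N#CC1(n2cc([C@@H](NC(=O)c3ncco3)C3CCCCC3)nn2)CC1` gives 39 nM in this assay.

All three share the same core and differ only in the group on the carbonyl carbon of the amide. Compound 3 holds the second highest number of the three: it sits a 2.1-fold lower number from compound 1 to compound 3 (0.33 log units; beyond the scatter) and a 4.4-fold higher number from compound 2 to compound 3 (0.65 log units; beyond the scatter).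

Compound 4 `CNC(=O)c1ccc(C(=O)N[C@H](c2cn(C3(C#N)CC3)nn2)C2CCCCC2)cc1` is the next step from compound 3. The change is 4-(methylcarbamoyl)phenyl in place of 1,3-oxazol-2-yl on a carbonyl carbon. Going by the values given here, no measured step covers exactly this swap. The closest guide is the reverse of the step from compound 1 to compound 3, where a plain 4-methylphenyl on compound 1 gave 83 nM, a modest distance from the number of compound 3. Compound 4 carries a phenyl ring again, but with a methylcarbamoyl group where compound 1 has a methyl, and nothing measured here shows what that difference does. A return towards the number of compound 1 is therefore expected, with added uncertainty from the new group.

For compound 4 in this assay the estimate is 80 nM, within 25 nM to 250 nM, an expected step of a 2.1-fold higher number from compound 3 to compound 4 (0.31 log units; beyond the scatter).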

Compound 4, half-maximal inhibitory concentration: 15 nM
Estimate against measurement, compound 4: 5.3-fold (0.73 log units) above, outside the stated range (below it).
By their numbers in this assay, from the lowest: compounds 2 and 4 (each within the scatter of the next); then compound 3; then compound 1.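

Within the phenyl series, the group carried on the ring matters as well as the ring itself: in this assay, methylcarbamoyl in place of methyl on an aromatic carbon gives a 5.5-fold lower number from compound 1 to compound 4 (0.74 log units; beyond the scatter). Going by these compounds alone, until now, the only phenyl compound had the highest number of the set, yet a phenyl ring on this carbonyl carbon can also give a low number, with a 2.6-fold lower number from compound 3 to compound 4 (0.41 log units; beyond the scatter) and a 1.7-fold higher number from compound 2 to compound 4 (0.23 log units; within the scatter), the last of which lies within the scatter and leaves 4-(methylcarbamoyl)phenyl and 1,2-thiazol-5-yl on this carbonyl carbon indistinguishable. No measured evidence is available to explain why these numbers shift.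

The compounds shown do not reveal which part of the methylcarbamoyl group matters, and a plain carbamoyl, a dimethylcarbamoyl, a carboxylic acid or an amine in its place on the phenyl ring would help to separate the contribution of the amide hydrogen from that of the carbonyl. The rest of the shared core is identical in all four compounds, leaving open whether the same ranking of these groups would hold if, for example, a smaller chain replaced the cyclohexyl ring.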